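This account rests on a few compounds, and the source may have more. Where it says the series, first, only, none or still open, it means among the compounds named here.

The three measured compounds, each tested in a functional assay on COLO 205 cells (Homo sapiens) for inhibition, read by sulforhodamine B assay, with a stated time of 48 h, tested at 50 uM; on this read-out higher numbers stand for more inhibition of growth at the one concentration tested and lower numbers for less inhibition of growth:

Compound 1 `O=C1C(=O)N(CCCCn2cc(COc3cc(=O)oc4ccccc34)nn2)c2ccccc21`: 68%
Compound 2 `O=C1C(=O)N(CCCCCn2cc(COc3cc(=O)oc4ccccc34)nn2)c2ccc(F)cc21`: 56%
Compound 3 `O=C1C(=O)N(CCCCCn2cc(COc3cc(=O)oc4ccccc34)nn2)c2ccccc21`: 62%

Compound 1 and compound 3 share the same pendant groups but differ in the chain that links them; the difference between the two cores is not broken down here. Their two values in this assay lie close to one another. Compound 2 is compound 3 carrying a fluoro in place of hydrogen on an aromatic carbon, and this change gave a number 6 percentage points lower from compound 3 to compound 2 (within the scatter).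

Compound 4 `O=C1C(=O)N(CCCCn2cc(COc3cc(=O)oc4ccccc34)nn2)c2ccc(F)cc21` has not yet been measured. It stands to compound 1 as compound 2 stands to compound 3, namely through (fluoro in place of hydrogen on an aromatic carbon), and the surroundings of the place are described in the same words for both pairs, so this is the same change. Because the earlier step was a number 6 percentage points lower from compound 3 to compound 2 (within the scatter), a step of similar size is expected here, a number 6 percentage points lower from compound 1 to compound 4 (within the scatter), staying within the scatter. Compound 4 is therefore estimated to reach 62% in this assay, with a likely range from 50% to 74%.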

Compound 4, percent growth inhibition at one concentration: 64%
Beside the measured number, compound 4's estimate is 2 percentage points below it, within the range that was stated.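

In this assay, fluoro in place of hydrogen on an aromatic carbon gave a number 4 percentage points lower from compound 1 to compound 4 (within the scatter) on the core of compound 1. Set beside the earlier step, the change carried over from one core to the other with much the same outcome: the same change on two cores in this assay, a number 6 percentage points lower (within the scatter) from compound 3 to compound 2 and a number 4 percentage points lower (within the scatter) from compound 1 to compound 4, 2 percentage points apart, within the scatter of two such steps. For the compounds shown here, this agreement rests on only two pairs of compounds whose cores differ in the chain, and as neither step leaves the scatter, it does not show that the fluoro has a real effect of its own on growth inhibition, nor that the same would hold on a core differing in some other way.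

The compounds shown leave open how a chloro, a methoxy or an amine at this same place on the ring would read, and whether a longer chain would keep the picture seen here. With one concentration and one cell line, they also leave open how these compounds would compare across a range of concentrations or on other cells.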